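The compounds below may be only part of what the source reports. "The series", "measured", "known", "first", "only" and "open" are said of these compounds alone.

Measured in a functional assay on A549 cells (Homo sapiens) for antiproliferative activity, read by MTT assay, with a stated time of 48 h; a higher number here means a weaker inhibitor, a lower number a stronger inhibitor:
Compound 1 `Cn1cc(-c2cnc3ccnc(N)c3c2)cn1`: 33400 nM
Compound 2 `Cn1cc(-c2cnc3ccc(NCc4ccc(F)cc4)nc3c2)cn1`: > 50000 nM

Among the measured compounds shown here, compound 1 holds the only actual number in this set, 33400 nM. Compound 2 gives only a limit of the assay, > 50000 nM, and not a number. Compound 3 `Cn1cc(-c2cnc3ccnc(NCc4ccc(F)cc4)c3c2)cn1` keeps the core of compound 1 and carries 4-fluorobenzyl in place of hydrogen on a nitrogen on an aromatic ring. For the measured compounds named here, no measured step covers this change, so no clear direction is expected in this assay. The estimated step of a 1.3-fold lower number from compound 1 to compound 3 (0.13 log units; within the scatter) stays within the usual scatter. Compound 3 is expected at 25000 nM, with an estimated range of 8000 nM to 50000 nM.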

Compound 3, half-maximal inhibitory concentration: 5200 nM
The estimate for compound 3 lay 4.8-fold (0.68 log units) above the measured number; measured number below the stated range.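

In this assay, 4-fluorobenzyl in place of hydrogen on a nitrogen on an aromatic ring gives a 6.4-fold lower number from compound 1 to compound 3 (0.81 log units; beyond the scatter), a modest step. This position therefore accepts a substituent of this size, and the change goes with a stronger inhibitor on the core of compound 1. Both values are actual numbers, clear of the assay's limit: the limit of > 50000 nM in this assay, at which 1 of the 3 values shown sits.

As far as these compounds go, it remains open whether the fluorine matters or whether any benzyl does. Plain benzyl, a longer chain such as 2-phenylethyl, or a small methyl on that nitrogen would help to separate these possibilities.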